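The compounds below may be only part of what the source reports. "The series", "measured", "known", "first", "only" and "open" are said of these compounds alone.

In a functional assay on A549 cells (Homo sapiens) for antiproliferative activity, read by MTT assay, with a stated time of 72 h (on this read-out higher numbers stand for weaker inhibition and lower numbers for stronger inhibition), the three measured compounds read as follows:
compound 1 `CCCSc1nc(Cl)c2c(n1)N(Cc1ccccc1)C(C(=O)N1CCN(Cc3ccccc3)CC1)N2` gives 14400 nM
compound 2 `CCCSc1nc(Cl)c2c(n1)N(Cc1cccs1)C(C(=O)N1CCN(C)CC1)N2` gives 6420 nM
compound 3 `CCCSc1nc(Cl)c2c(n1)N(Cc1ccccc1)C(C(=O)N1CCN(C)CC1)N2` gives 2800 nM

Compound 3 stands lowest of the three in this assay, with compound 2 nearest and compound 1 furthest, as the steps of a 5.1-fold lower number from compound 1 to compound 3 (0.71 log units; beyond the scatter) and a 2.3-fold lower number from compound 2 to compound 3 (0.36 log units; beyond the scatter) show. Compound 4 `CCCSc1nc(Cl)c2c(n1)N(Cc1ccco1)C(C(=O)N1CCN(C)CC1)N2` differs from compound 3 in one place: furan-2-yl in place of phenyl on a saturated chain carbon bound to a nitrogen on an aromatic ring in a ring. Within the data shown here, only one measured step bears on this change, a 2.3-fold lower number from compound 2 to compound 3 (0.36 log units; beyond the scatter), in which a five-membered aromatic ring with one hetero atom at the same place gave the higher number; compound 4 reverses that kind of exchange. A modest step upward is therefore expected in this assay for compound 4, roughly a 2.0-fold higher number from compound 3 to compound 4 (0.29 log units; within the scatter). Compound 4 is estimated at 5500 nM, with a range from 2200 nM to 14000 nM.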

Compound 4, half-maximal inhibitory concentration: 13600 nM
Compound 4: middle estimate off by 2.5-fold (0.39 log units), on the low side, and the stated range covers the measured number.
By their numbers in this assay, from the lowest: compound 3; then compound 2; then compounds 4 and 1 (each within the scatter of the next).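

In this assay, the exchange on a saturated chain carbon bound to a nitrogen on an aromatic ring in a ring gives a 4.9-fold higher number from compound 3 to compound 4 (0.69 log units; beyond the scatter), so the furan-2-yl group gives up more than the thiophen-2-yl group did. The two five-membered rings also differ from each other, with a 2.1-fold higher number from compound 2 to compound 4 (0.33 log units; beyond the scatter), which sets phenyl, thiophen-2-yl and furan-2-yl in rising order of number. No measurement at hand explains this order. The compounds shown leave open how a pyridin-2-yl ring or a saturated cyclohexyl ring would read at this place.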